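Sulfonamide nitrogen substituent: benzyl to 4-methylphenyl

The compounds below may be only part of what the source reports. "The series", "measured", "known", "first", "only" and "open" are said of these compounds alone.

Working notes on the amide-sulfonamide series. In a functional assay on HEK293 cells for agonist activity at probable G-protein coupled receptor 27 (Homo sapiens), read by a luciferase reporter and beta-arrestin recruitment, with a stated time of 10 min (a higher number here means that more compound is needed for the effect, a lower number that less compound is needed), compound 1 `O=C(Nc1ccc(S(=O)(=O)NCc2ccccc2)cc1)c1ccc(Cl)cc1Cl` gives > 100000 nM, which is a limit of the assay and not a number; it stands at the limit of > 100000 nM in this assay, at which 1 of the 3 values shown sits. Compound 2 `N#Cc1ccc(C(=O)Nc2ccc(S(=O)(=O)Nc3ccccc3)cc2)c(F)c1` gives 229 nM in this assay, and compound 3 `O=C(Nc1ccc(S(=O)(=O)Nc2ccccc2)cc1)c1ccc(Cl)cc1Br` gives 1020 nM. Among the compounds with values here, the one measured step, a 4.5-fold higher number from compound 2 to compound 3 (0.65 log units; beyond the scatter), concerns the aryl group on the carbonyl carbon, not the sulfonamide nitrogen.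

Compound 4 `Cc1ccc(NS(=O)(=O)c2ccc(NC(=O)c3ccc(Cl)cc3Cl)cc2)cc1` differs from compound 1 by 4-methylphenyl in place of benzyl on a sulfonamide nitrogen. Within the data shown here, no measured step covers this change directly; what bears on it is that compound 2 and compound 3, both carrying phenyl on the sulfonamide nitrogen, give numbers in this assay, while compound 1 with benzyl there gives only a limit. Compound 3, whose 2-bromo-4-chlorophenyl group is the nearest match to the 2,4-dichlorophenyl group of compound 4, serves as the reference point. The expected step of an at least 50-fold lower number from compound 1 to compound 4 (1.69 log units; beyond the scatter) is therefore toward a lower number, of a size that cannot be fixed from a limit.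

For compound 4 the estimate in this assay is 2000 nM, within 300 nM to 30000 nM, with a real chance that only a limit is again returned.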

Compound 4, half-maximal effective concentration: > 100000 nM
Compound 4: a limit, no number (the forecaster's own chance of this, stated with the estimate: 30%); at least 50-fold (1.69 log units) between middle value and limit.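

Compound 1 and compound 4 each return only a limit of the assay in this assay, so no step between them can be read: the limit of > 100000 nM in this assay, at which 2 of the 4 values shown sit.

Left open is what number, if any, benzyl or 4-methylphenyl on the sulfonamide nitrogen would give alongside the 2,4-dichlorophenyl group on the carbonyl carbon.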